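The compounds below may be only part of what the source reports. "The series", "measured", "known", "first", "only" and "open" are said of these compounds alone.

In an ADME assay on HeLa cells (Homo sapiens) for cytotoxicity, read by crystal violet staining, with a stated time of 72 h (on this read-out higher numbers stand for lower toxicity in this test and lower numbers for higher toxicity in this test), compound 3 (`CC(=O)Nc1cc(-c2noc(C(F)(F)F)n2)ccc1OCCCc1cc(C(=O)N(C)C)no1`) reads > 100000 nM, which is a limit of the assay and not a number. Compound 4 (`CN(C)C(=O)c1cc(CCCOc2ccc(-c3noc(C(F)(F)F)n3)cc2-n2cccc2)on1`) has 1H-pyrrol-1-yl in place of acetamido on an aromatic carbon.

Within the data shown here, the only measured step that bears on this position is an at least 3.5-fold higher number from compound 1 to compound 3 (0.55 log units; beyond the scatter), in which acetamido takes the place of hydrogen. Compound 1 (`CN(C)C(=O)c1cc(CCCOc2ccc(-c3noc(C(F)(F)F)n3)cc2)on1`) gives 28000 nM. Among the measured compounds shown here, no measured step covers the exchange of acetamido for 1H-pyrrol-1-yl. The closest guide is compound 2 (`CCOC(=O)c1cc(CCCOc2ccc(-c3noc(C(F)(F)F)n3)cc2-n2cccc2)on1`), which carries 1H-pyrrol-1-yl with an ethyl ester in place of the dimethyl amide and gives 57300 nM.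

Losing the acetamido may therefore give back part or all of the size of the step into compound 3, so a move towards lower numbers in this assay is expected. The expected change is an at least 2.0-fold lower number from compound 3 to compound 4 (0.30 log units; that floor lies within the scatter). For compound 4 the estimated value is 50000 nM, with an expected range of 20000 nM to 100000 nM.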

Compound 4, half-maximal cytotoxic concentration: 21200 nM
Beside the measured number, compound 4's estimate is 2.4-fold (0.37 log units) above it; measured number inside the range.
By their numbers in this assay, from the lowest: compounds 4 and 1 (each within the scatter of the next); then compound 2. At a limit, above all of these: compound 3.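

In this assay, 1H-pyrrol-1-yl and hydrogen at this position read alike with the dimethyl amide in place: a 1.3-fold lower number from compound 1 to compound 4 (0.12 log units; within the scatter). The exchange of acetamido for 1H-pyrrol-1-yl gives an at least 4.7-fold lower number from compound 3 to compound 4 (0.67 log units; beyond the scatter), so among the three groups seen here only acetamido separates from the others, and the value of compound 3 is a limit of the assay and not a number: the limit of > 100000 nM in this assay, at which 1 of the 4 values shown sits. With 1H-pyrrol-1-yl held in place, the other end of the molecule also counts, as dimethylamino in place of ethoxy on a carbonyl carbon gives a 2.7-fold lower number from compound 2 to compound 4 (0.43 log units; beyond the scatter).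

As far as these compounds go, whether a primary amine or an N-methylacetamido group at this position would read with compound 3 or with compound 1 stays open. Also open, from the compounds shown here alone, is whether an ethyl ester would shift the number in the same direction with acetamido at this position.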